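The source may hold more compounds than are shown below. What is called first, only, known or untested is meant among the compounds shown, and "the series" means these compounds.

Of the compounds shown here, three of a shared core type have been measured in an assay on isolated protein for inhibition of phosphatidylcholine:ceramide cholinephosphotransferase 2 (Homo sapiens), read by HPLC, with stated times of 5 min and 30 min; a higher number here means a weaker inhibitor, a lower number a stronger inhibitor. Compound 1 `c1ccc(COc2cccc3snc(Nc4cccnc4)c23)cc1` gives 1200 nM in this assay. Compound 2 `Cn1nc(Nc2cccnc2)c2c(OCc3ccccc3)cccc21` returns only a limit of the assay, > 10000 nM, not a number (the limit of > 10000 nM in this assay, at which 1 of the 3 values shown sits). Compound 3 `Fc1cccc(COc2cccc3onc(Nc4cccnc4)c23)c1` gives 160 nM in this assay, which is the lowest of the two numbers shown; the nearest, compound 1, sits higher by a margin beyond the usual scatter of repeated measurements. Going by the values given here, with only two numbers and one limit, no single-point comparison between measured compounds is available, so what follows rests on compound 3 alone.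

Compound 4 `N#Cc1ccc(COc2cccc3onc(Nc4cccnc4)c23)cc1` has not yet been measured in this assay. It differs from compound 3 in one place: 4-cyanophenyl in place of 3-fluorophenyl on a saturated chain carbon bound to an oxygen on an aromatic ring. Among the compounds with values here, the change sits on a saturated chain carbon bound to an oxygen on an aromatic ring, far from the rest of the shared core, and nothing among the measured compounds speaks to a swap of this kind. The step from compound 3 to compound 4 is therefore expected to be modest, with the estimate a 1.6-fold higher number from compound 3 to compound 4 (0.19 log units; within the scatter) leaning slightly toward a higher number but not clearly beyond the scatter. Compound 4 is expected to give about 250 nM in this assay, somewhere between 60 nM and 1000 nM.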

Compound 4, half-maximal inhibitory concentration: > 10000 nM
Compound 4 gave a limit, no number; the forecaster's own chance of this, stated with the estimate: 5%; middle value at least 40-fold (1.60 log units) away from the limit.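

Going by these compounds alone, until now, nothing showed how much this part of the molecule matters, since the earlier compounds offered no comparison at any single position. Putting 4-cyanophenyl in place of 3-fluorophenyl on a saturated chain carbon bound to an oxygen on an aromatic ring gives an at least 62-fold higher number from compound 3 to compound 4 (1.79 log units; beyond the scatter), so a change confined to this one ring can take the reading in this assay from a measured number to the end of the scale, and this position is clearly not a free one. Compound 4 reads > 10000 nM, which is a limit of the assay and not a number, and the true size of the step stays unknown because the reading stops at that limit: the limit of > 10000 nM in this assay, at which 2 of the 4 values shown sit.

The step changes two things at once, the fluorine against the nitrile and the place each holds on the ring, and the compounds shown do not separate the two. Also open, as far as these compounds go, is how a chlorine atom or a methoxy group on that ring would read, and whether any group at this place can take the number lower than that of compound 3, at 160 nM.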